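Nitro for Chloro: Cytotoxicity Expected to Stay Weak

This account rests on a few compounds, and the source may have more. Where it says the series, first, only, none or still open, it means among the compounds named here.

Compound 1 `COc1ccc(/C=C2\S/C(=N\c3ccc(C(C)(C)C)cc3)N(C)C2=O)cc1` gives 46700 nM in an ADME assay on TERT-RPE1 cells (Homo sapiens) for cytotoxicity, read by MTT assay, with a stated time of 72 h; a lower number here means a stronger inhibitor, a higher number a weaker inhibitor.
Compound 2 `COc1ccc(/C=C2/CN(C)/C(=N/c3ccc(Cl)cc3)S2)cc1` gives 39600 nM in this assay.
Compound 3 `FC(F)(F)c1cc(/N=C2/NC/C(=C/c3ccccc3)S2)cc(C(F)(F)F)c1` gives 32800 nM in this assay.

The three compounds share a sulfur-containing core carrying a styryl-type arm and an aryl imine, and all three are weak inhibitors of cell viability in this assay. Compound 2 lies among them: its difference from compound 1, its nearest neighbour, is within the usual scatter, and so is its difference from compound 3, the furthest of the three. On the numbers shown, then, nothing separates compound 2 from the others beyond measurement noise.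

Compound 4 `COc1ccc(/C=C2/CN(C)/C(=N/c3ccc([N+](=O)[O-])cc3)S2)cc1` is the next compound to be tested. It is built from compound 2 by a single change: nitro in place of chloro on an aromatic carbon. Among the measured compounds shown here, no step between measured compounds that differ in just one place is available, so there is no direct precedent for this swap. Given how tightly the three measured values cluster, the expectation for this assay is a step of no size beyond the scatter, in either direction. Compound 4 is therefore expected to give about 40000 nM, with a range from 20000 nM to 80000 nM, which corresponds to an expected step of a 1.0-fold higher number from compound 2 to compound 4 (0.00 log units; within the scatter).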

Compound 4, half-maximal inhibitory concentration: > 100000 nM
Compound 4 gave a limit, no number (the forecaster's own chance of this, stated with the estimate: 10%); middle value at least 2.5-fold (0.39 log units) from the limit.
By their numbers in this assay, from the lowest: compounds 3, 2 and 1 (each within the scatter of the next). At a limit, above all of these: compound 4.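

Among the compounds shown here, this is the first step between two measured compounds that differ in just one place, and it shows that this position, on an aromatic carbon para to a large group, is not indifferent to what sits there: nitro in place of chloro gives an at least 2.5-fold higher number from compound 2 to compound 4 (0.40 log units; beyond the scatter) in this assay. The reading for compound 4 is a limit of the assay and not a number: the limit of > 100000 nM in this assay, at which 1 of the 4 values shown sits. For the compounds shown here, the step therefore has a floor but no known size, and it makes one thing clear that the earlier compounds could not: their close agreement, among structures that differ in more than one place, gave no sign that a single swap on this ring could carry a compound beyond the scatter.

The compounds shown leave open whether an amine, a carboxylic acid or a nitrile at the same place would move the number in the same way, or whether the effect belongs to nitro alone. They also leave open whether the same swap would have a similar effect on the core of compound 1 or compound 3, and they give no measured property that would explain the step.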